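A few compounds are considered here, and "the series" means these few. Any claim that something is new, unique, unknown or untested is made for them only; others in the source may bear on it.

Among the measured compounds shown here, compound 2, `Cc1nc(C(c2ccc(-c3ccc4cccc(F)c4c3)[nH]c2=O)C(C)C)[nH]c1C`, gives the lower of the two numbers so far in a functional assay on CHO cells for antagonist activity at prostaglandin E2 receptor EP3 subtype (Homo sapiens), read by cAMP accumulation (on this read-out higher numbers stand for weaker inhibition and lower numbers for stronger inhibition), at 50 nM, while compound 1, `CC(C)C(c1ncco1)c1ccc(-c2ccc3cccc(F)c3c2)[nH]c1=O`, gives 64 nM. The step between them, a 1.3-fold lower number from compound 1 to compound 2 (0.11 log units; within the scatter), changed the five-membered heteroaryl ring on the saturated chain carbon bound to an aromatic carbon and a saturated chain carbon. Compound 3, `CC(C)C(c1nnc[nH]1)c1ccc(-c2ccc3cccc(F)c3c2)[nH]c1=O`, alters the same place again: 4H-1,2,4-triazol-3-yl in place of 4,5-dimethyl-1H-imidazol-2-yl on a saturated chain carbon bound to an aromatic carbon and a saturated chain carbon. For the measured compounds named here, only that one measured step bears on this change, and it stayed within the scatter, so exchanging one small azole for another at this position has so far left this assay essentially unmoved. Compound 3 is therefore expected to show no step beyond the scatter, with a 1.2-fold higher number from compound 2 to compound 3 (0.08 log units; within the scatter) as the estimated change. The estimate for compound 3 in this assay is 60 nM, with a range from 25 nM to 150 nM.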

Compound 3, half-maximal inhibitory concentration: 21 nM
Beside the measured number, compound 3's estimate is 2.9-fold (0.46 log units) above it, and the stated range ends above it.
By their numbers in this assay, from the lowest: compound 3; then compounds 2 and 1 (each within the scatter of the next).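

Here the choice of azole on the saturated chain carbon does move the number in this assay: the 4H-1,2,4-triazol-3-yl group gives a 2.4-fold lower number from compound 2 to compound 3 (0.38 log units; beyond the scatter) when it replaces the 4,5-dimethyl-1H-imidazol-2-yl group and a 3.0-fold lower number from compound 1 to compound 3 (0.48 log units; beyond the scatter) when it replaces the 1,3-oxazol-2-yl group. The earlier exchange of one azole for another therefore did not show that this position is indifferent to the ring, although both new steps are modest. In the exchange from compound 2 to compound 3, the loss of carbon, the added ring nitrogen and the added hydrogen-bond acceptor all arrive together, and nothing measured here separates them or explains the step.

On these data alone, whether a tetrazole or a carboxylic acid at this carbon would continue the trend remains open. So does whether a methyl group on the triazole would reverse it.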